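The source may hold more compounds than are shown below. What is called first, only, known or untested is meant among the compounds shown, and "the series" means these compounds.

Measured compounds:
- compound 1, `Cc1nc(C)c(/C=C/C(=O)c2ccc(NC(=O)c3ccccc3F)cc2)nc1C`: 2040 nM
- compound 2, `Cc1ccc(C(=O)Nc2ccc(C(=O)/C=C/c3nc(C)c(C)nc3C)cc2)cc1`: 5450 nM
- compound 3, `COc1ccc(C(=O)Nc2ccc(C(=O)/C=C/c3nc(C)c(C)nc3C)cc2)cc1`: 1190 nM

These three share one core and differ only in the aromatic group joined to the amide carbonyl. In a functional assay on HepG2 cells (Homo sapiens) for antiproliferative activity, read by CCK-8 assay, with a stated time of 72 h (a higher number here means a weaker inhibitor, a lower number a stronger inhibitor), compound 3 gives the lowest of the three numbers; its nearest neighbour is compound 1, with a 1.7-fold lower number from compound 1 to compound 3 (0.23 log units; within the scatter) lying within the scatter, while the step of a 4.6-fold lower number from compound 2 to compound 3 (0.66 log units; beyond the scatter) is beyond it. The step of a 2.7-fold higher number from compound 1 to compound 2 (0.43 log units; beyond the scatter) shows how much this one group can move the number.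

Compound 4, `COc1cc(OC)cc(C(=O)Nc2ccc(C(=O)/C=C/c3nc(C)c(C)nc3C)cc2)c1`, carries the change (3,5-dimethoxyphenyl in place of 4-methoxyphenyl on a carbonyl carbon). For the measured compounds named here, none of the measured steps changes a methoxy-bearing ring in this way, so they bear on it only loosely: swapping one aromatic group for another has given steps from modest to within the scatter. Compound 4 is therefore expected to stay near compound 3, with the estimated step of a 1.0-fold higher number from compound 3 to compound 4 (0.00 log units; within the scatter) and an estimate of 1200 nM (range 400 nM to 3500 nM) in this assay.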

Compound 4, half-maximal inhibitory concentration: 11000 nM
The estimate for compound 4 lay 9.2-fold (0.96 log units) below the measured number; the measured number lies above the stated range.
By their numbers in this assay, from the lowest: compounds 3 and 1 (each within the scatter of the next); then compounds 2 and 4 (each within the scatter of the next).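

In this assay, the change from 4-methoxyphenyl to 3,5-dimethoxyphenyl on the amide carbonyl gives a 9.2-fold higher number from compound 3 to compound 4 (0.97 log units; beyond the scatter), the largest step yet seen at this position, so carrying methoxy on this ring does not by itself keep the number low. Set against the 2-fluorophenyl group, the 3,5-dimethoxyphenyl group gives a 5.4-fold higher number from compound 1 to compound 4 (0.73 log units; beyond the scatter), whereas against the 4-methylphenyl group it gives a 2.0-fold higher number from compound 2 to compound 4 (0.30 log units; within the scatter), so this last pair cannot be put in order. Nothing available explains why the number rises so far with this group.

The compounds shown leave open whether the rise follows from the added methoxy itself or from where the methoxy groups sit on the ring. They also leave open how the number would move with an amine or a carboxylic acid on this aromatic group.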